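Moving the methyl branch along the side chain of compound 2

The compounds below may be only part of what the source reports. "The series", "measured", "known", "first", "only" and "open" are said of these compounds alone.

Measured compounds:
compound 1 `CCCCCCCc1cc(=O)c2ccccc2[nH]1` 35000 nM
compound 2 `CC(C)CCCCCc1cc(=O)c2ccccc2[nH]1` 34000 nM

Both compounds share a core that carries a saturated side chain. In an ADME assay on A2780 cells (Homo sapiens) for antiproliferative activity, read by resazurin assay, with a stated time of 2 days (a lower number here means a stronger inhibitor, a higher number a weaker inhibitor), compound 1 gives 35000 nM and compound 2 gives 34000 nM, two numbers within the scatter of each other, so neither can be called the stronger. Within the data shown here, the only measured step, a 1.0-fold lower number from compound 1 to compound 2 (0.01 log units; within the scatter), shows that adding a methyl branch to the chain end changed nothing that can be resolved.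

Compound 3 `CCCC(C)CCCc1cc(=O)c2ccccc2[nH]1` is the unmeasured isomer: 1-methylbutyl in place of isopentyl on a saturated chain carbon, three bonds along the chain from an aromatic carbon. The same atoms are joined differently, with the branch moved inward. Among the measured compounds shown here, the single step that bears on it was flat, and nothing here suggests that shifting the branch along the chain should register. The expected step is therefore no change at the digits printed from compound 2 to compound 3 (within the scatter), none beyond the scatter. Compound 3 is estimated at 34000 nM, within 15000 nM to 75000 nM.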

Compound 3, half-maximal inhibitory concentration: 29000 nM
For compound 3 the middle estimate is 1.2-fold (0.07 log units) above the measured one; the measured number falls inside the stated range.
By their numbers in this assay, from the lowest: compounds 3, 2 and 1 (each within the scatter of the next).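

Moving the branch inward, with 1-methylbutyl in place of isopentyl on a saturated chain carbon, three bonds along the chain from an aromatic carbon, gives a 1.2-fold lower number from compound 2 to compound 3 (0.07 log units; within the scatter) in this assay. Set against the unbranched chain, the inward branch gives a 1.2-fold lower number from compound 1 to compound 3 (0.08 log units; within the scatter), so the two placements of the methyl branch can be told apart neither from each other nor from the unbranched chain, whereas the earlier step covered only the branch at the chain end. No measurement bears on why these numbers stay so close.

On these data alone, what stays open is whether a longer chain would give a number beyond the scatter of these three compounds. The same question stands for an amine or a carboxylic acid carried on the side chain.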